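The source may hold more compounds than are shown below. What is called first, only, known or untested is meant among the compounds shown, and "the series" means these compounds.

Measured so far:
- compound 1, `COc1cc(-c2cc(/C=C/C(=O)c3ccc(Cl)c(Cl)c3)[nH]n2)cc(OC)c1OC`, giving 92% in a functional assay on NCI-H522 cells (Homo sapiens) for cytotoxicity, read by sulforhodamine B assay, with a stated time of 48 h, tested at 0.01 uM; on this read-out higher numbers stand for a weaker effect at the one concentration tested and lower numbers for a stronger effect
- compound 2, `COc1ccc(-c2cc(/C=C/C(=O)c3cc(OC)c(OC)c(OC)c3)[nH]n2)cc1OC`, giving 89% in this assay
- compound 3, `COc1ccc(C(=O)/C=C/c2cc(-c3cc(OC)c(OC)c(OC)c3)n[nH]2)cc1`, giving 83% in this assay

All three compounds share a common core and differ only in the group attached to the carbonyl carbon. Compound 3 shows the lowest of the three numbers, but its gaps to compound 2 and to compound 1 both lie within the usual scatter, so the three compounds cannot be told apart on these data.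

Compound 4, `COc1cc(-c2cc(/C=C/C(=O)c3ccc(F)c(F)c3)[nH]n2)cc(OC)c1OC`, has not yet been measured in this assay. Its difference from compound 3 is 3,4-difluorophenyl in place of 4-methoxyphenyl on a carbonyl carbon.

Going by the values given here, one measured step bears on this change: a number 9 percentage points lower from compound 1 to compound 3 (within the scatter). That step swapped a halogen-bearing phenyl for the 4-methoxyphenyl and produced no shift beyond the scatter. The move to compound 4 puts a halogen-bearing phenyl back in the same place, so a step of similar small size, in either direction or none at all, is expected. The estimate for compound 4 is therefore 88%, in the range from 78% to 98%, which means an expected step of a number 5 percentage points higher from compound 3 to compound 4 (within the scatter).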

Compound 4, a percentage reported as activity, at one concentration (the size of the read-out at that concentration, not a potency): 96%
Compound 4: middle estimate off by 8 percentage points, on the low side, within the range that was stated.
By their numbers in this assay, from the lowest: compounds 3, 2, 1 and 4 (each within the scatter of the next, the first and the last beyond it).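

In this assay, going by these compounds alone, the change at this carbonyl carbon gives the first step beyond the scatter, a number 13 percentage points higher from compound 3 to compound 4 (beyond the scatter), though it is only a modest one. This shows that the group in this place can register in the read-out, at least between 4-methoxyphenyl and 3,4-difluorophenyl, whereas the earlier step between 3,4-dichlorophenyl and 4-methoxyphenyl did not show this. The two halogen-bearing groups cannot be told apart, with a number 4 percentage points higher from compound 1 to compound 4 (within the scatter) as the step between them, and nothing measured here accounts for the separation between compound 3 and compound 4.

Every group shown on this carbonyl carbon is a substituted phenyl ring, so it remains open how an amine, a carboxylic acid or a longer chain in the same place would read. All of these numbers also come from the one concentration tested, which leaves open whether the separation between compound 3 and compound 4 would persist at other concentrations or would appear as a difference in potency.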